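The source may hold more compounds than are shown below. What is called first, only, known or untested is meant among the compounds shown, and "the series" means these compounds.

Cell toxicity is followed here through an ADME assay on Huh-7 cells (Homo sapiens) for cytotoxicity; on this read-out higher numbers stand for lower toxicity in this test and lower numbers for higher toxicity in this test. Compound 1 `COc1ccc2c(c1)C=C1Cn3c-2c(C2CCCCC2)c2ccc(cc23)C(=O)NS(=O)(=O)N(C)CCCCNC1=O` and compound 2 `COc1ccc2c(c1)[C@H]1C[C@@]13Cn1c-2c(C2CCCCC2)c2ccc(cc21)C(=O)NS(=O)(=O)N(C)CCOCCN(C)C3=O` have both been tested. Compound 1 gives > 25000 nM, which is a limit of the assay and not a number. Compound 2 gives > 25000 nM, which is also a limit. Compound 2 therefore stands at the limit of > 25000 nM in this assay, at which 2 of the 2 values shown sit, with no exact number to start from.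

Compound 3 `COc1ccc2c(c1)[C@@H]1C[C@]13Cn1c-2c(C2CCCCC2)c2ccc(cc21)C(=O)NS(=O)(=O)N(C)CCOCCN(C)C3=O` has the same atoms and bonds as compound 2, and the two are mirror images: the two compounds have the same atoms and bonds and differ only in configuration as drawn: 2 of 2 stereo elements differ (all stereocentres are inverted: mirror images); a stereocentre at a saturated ring carbon is drawn R in compound 2 and S in compound 3; a stereocentre at a saturated ring carbon is drawn S in compound 2 and R in compound 3. For the measured compounds named here, one stereocentre at a saturated ring carbon is drawn R in compound 2 and S in compound 3, and the other is drawn S and then R. No measured pair shows what such an inversion does, so in this assay no change beyond the scatter is expected. The estimated change is a step that the limit leaves unreadable from compound 2 to compound 3. The expected value for compound 3 is 30000 nM, within an estimated range of 15000 nM to 60000 nM.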

Compound 3, half-maximal cytotoxic concentration: > 25000 nM
Compound 3: a limit, no number; the forecaster's own chance of this, stated with the estimate: 80%; the middle value is on the limit's open side.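

In this assay compound 3 also gives only a limit, like compound 2, so no step between these two mirror images can be read: the limit of > 25000 nM in this assay, at which 3 of the 3 values shown sit.

The compounds shown leave open whether inverting both stereocentres changes cell toxicity at all, and where the exact value of each compound lies.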